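This account rests on a few compounds, and the source may have more. Where it says the series, first, only, none or still open, it means among the compounds named here.

Measured compounds:
- compound 1, `COc1cc2nc(N3CCN(C(C)=O)[C@H]4CCCC[C@H]43)nc(N)c2cc1OC`: 9.12 nM
- compound 2, `CCCCCC(=O)N1CCN(c2nc(N)c3cc(OC)c(OC)cc3n2)[C@@H]2CCCC[C@@H]21`: 0.912 nM
- compound 3, `COc1cc2nc(N3CCN(C(=O)OCc4ccccc4)[C@H]4CCCC[C@H]43)nc(N)c2cc1OC`: 0.38 nM

All three were tested in an assay on CHO cells for displacement of a labelled ligand from Alpha-1B adrenergic receptor (Homo sapiens), with a stated time of 30 min; on this read-out lower numbers stand for stronger inhibition and higher numbers for weaker inhibition. Compound 1 shows the highest number of the three, so it is the weakest binder here: compound 2 lies nearest, a 10-fold lower number from compound 1 to compound 2 (1.00 log units; beyond the scatter), and compound 3 furthest, a 24-fold lower number from compound 1 to compound 3 (1.38 log units; beyond the scatter). Between compound 2 and compound 3 the gap is smaller, a 2.4-fold lower number from compound 2 to compound 3 (0.38 log units; beyond the scatter).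

Compound 4, `COc1cc2nc(N3CCN(C(C)=O)[C@@H]4CCCC[C@@H]43)nc(N)c2cc1OC`, has not yet been measured. It differs from compound 1 as follows: the two compounds have the same atoms and bonds and differ only in configuration as drawn: 2 of 2 stereo elements differ (all stereocentres are inverted: mirror images); a stereocentre at a saturated ring carbon is drawn S in compound 1 and R in compound 4; a stereocentre at a saturated ring carbon is drawn R in compound 1 and S in compound 4. Every measured step above changes the group on the carbonyl carbon and leaves the ring configuration untouched, so none of them bears on a mirror-image change. For the measured compounds named here, the data therefore give no direction for this step. Mirror-image pairs commonly differ in binding, in either direction, so a shift beyond the scatter is plausible but its sign is uncertain. For compound 4 in this assay the estimate is 15 nM, with a wide range from 1.5 nM to 150 nM, which means an expected step of a 1.6-fold higher number from compound 1 to compound 4 (0.22 log units; within the scatter).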

Compound 4, inhibition constant: 0.741 nM
For compound 4 the middle estimate is 20-fold (1.31 log units) above the measured one, outside the stated range (below it).
By their numbers in this assay, from the lowest: compounds 3, 4 and 2 (each within the scatter of the next, the first and the last beyond it); then compound 1.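

Inverting both stereocentres at the saturated ring carbons, with the methyl on the carbonyl carbon kept in place, gives a 12-fold lower number from compound 1 to compound 4 (1.09 log units; beyond the scatter) in this assay. The earlier steps shown here all changed the group on the carbonyl carbon, whereas this one shows that configuration alone can move the number, here to an extent comparable with a 10-fold lower number from compound 1 to compound 2 (1.00 log units; beyond the scatter). The shift can be assigned to configuration and nothing else, because no atom or bond changes: the fact that compounds 1 and 4 differ only in the configuration as drawn

Going by these compounds, compound 2 and compound 3 appear only in the configuration of compound 1, so it remains open whether inversion would lower their numbers as well. Also open, on these data alone, is how each configuration would respond to an amine, a carboxylic acid or a longer chain on the carbonyl carbon.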